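Fluoro in Place of Nitro: Expecting Little Change

The compounds below may be only part of what the source reports. "The series", "measured", "known", "first", "only" and "open" are said of these compounds alone.

Two measured compounds set the scene. Compound 1 `Cc1cc(NC(=O)Cn2cc(-c3ccc([N+](=O)[O-])cc3)nn2)no1` was tested in a functional assay on BMDM cells (Mus musculus, strain C57BL/6) for inhibition, with a stated time of 2 days (on this read-out lower numbers stand for stronger inhibition and higher numbers for weaker inhibition), where compound 1 gives 1220 nM. Compound 2 `Cc1csc(NC(=O)Cn2cc(-c3ccccc3Cl)nn2)n1` carries a different core and a different substituted aromatic ring; in this assay compound 2 gives 1240 nM. Compound 1 holds the lower of the two numbers, yet the two values sit within the usual scatter of each other, so they show no real difference between the two compounds.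

Compound 3 `Cc1cc(NC(=O)Cn2cc(-c3ccc(F)cc3)nn2)no1` keeps the core of compound 1 and differs in one place: fluoro in place of nitro on an aromatic carbon. Among the measured compounds shown here, no measured pair in this set shares a change of this kind, so there is no step to lean on, and the two measured values give no guide to how a nitro group compares with a fluoro group. The expected step in this assay is therefore small, with no direction claimed beyond the scatter, and the expected step is a 1.5-fold higher number from compound 1 to compound 3 (0.17 log units; within the scatter). Compound 3 is estimated at 1800 nM, with a range from 600 nM to 5000 nM.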

Compound 3, half-maximal inhibitory concentration: > 30000 nM
Compound 3 gave a limit, no number; the forecaster's own chance of this, stated with the estimate: 5%; middle value at least 16-fold (1.22 log units) away from the limit.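

The earlier compounds shown here offered no single change to read, whereas this pair does, and it shows that the aromatic carbon para to a large group is far from indifferent to what it carries: in this assay, fluoro in place of nitro gives an at least 24-fold higher number from compound 1 to compound 3 (1.39 log units; beyond the scatter). Compound 3 reads > 30000 nM, which is a limit of the assay and not a number, and the only fact on record that bears on this reading is that limit itself: the limit of > 30000 nM in this assay, at which 1 of the 3 values shown sits. The change replaces a group of 3 heavy atoms and 2 hydrogen-bond acceptors with one of 1 heavy atom and 0 hydrogen-bond acceptors, yet a single pair cannot tell which of these differences, if either, matters.

With only nitro and fluoro shown at this carbon on the core of compound 1, it remains open whether inhibition tracks the size of the group, its acceptors or something else entirely. A nitrile, a methyl group or an amine at the same carbon would each test whether nitro is special here or merely one of several groups that keep inhibition intact.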